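From 3-methoxyphenyl to 4-methoxyphenyl: compound 3 and compound 4

The compounds below may be only part of what the source reports. "The series", "measured", "known", "first", "only" and "open" are said of these compounds alone.

Measured in a functional assay on HeLa cells (Homo sapiens) for antiproliferative activity, read by MTT assay, with a stated time of 72 h; a lower number here means a stronger inhibitor, a higher number a weaker inhibitor:
- compound 1 `COc1cc(-c2nccn2C(C)C)cc(OC)c1OC`: > 100000 nM (a limit)
- compound 2 `COc1ccc(-n2ccnc2-c2cc(OC)c(OC)c(OC)c2)cc1[N+](=O)[O-]`: 2500 nM
- compound 3 `COc1cccc(-n2ccnc2-c2cc(OC)c(OC)c(OC)c2)c1`: 11000 nM

Of the two actual numbers, compound 3 has the higher, 11000 nM, against compound 2 at 2500 nM, a gap beyond the scatter. Compound 4 `COc1ccc(-n2ccnc2-c2cc(OC)c(OC)c(OC)c2)cc1` carries 4-methoxyphenyl in place of 3-methoxyphenyl on an aromatic nitrogen. Within the data shown here, the only measured step, an at least 9.0-fold lower number from compound 1 to compound 3 (0.95 log units; beyond the scatter), replaces isopropyl and so gives no direct size for this move. Compound 2, at 2500 nM, has a methoxy group plus a nitro group on its aromatic ring, which gives weak support for a lower number. Expected in this assay is a modest move, a 3.7-fold lower number from compound 3 to compound 4 (0.56 log units; beyond the scatter). For compound 4 the estimate is 3000 nM, with an expected range of 500 nM to 15000 nM.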

Compound 4, half-maximal inhibitory concentration: 1200 nM
For compound 4 the middle estimate is 2.5-fold (0.40 log units) above the measured one; low and high end bracket the measured number.
By their numbers in this assay, from the lowest: compound 4; then compound 2; then compound 3. At a limit, above all of these: compound 1.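

In this assay, the same atoms joined differently give a 9.2-fold lower number from compound 3 to compound 4 (0.96 log units; beyond the scatter), so 4-methoxyphenyl in place of 3-methoxyphenyl on the aromatic nitrogen matters in itself. With hydrogen in place of nitro, the series shows a 2.1-fold lower number from compound 2 to compound 4 (0.32 log units; beyond the scatter), so the nitro group is not required for the lower number. Compound 1 stands at a limit, so an at least 83-fold lower number from compound 1 to compound 4 (1.92 log units; beyond the scatter) gives only a bound: the limit of > 100000 nM in this assay, at which 1 of the 4 values shown sits.

Open, from the compounds shown here alone, is how an amine or an ethoxy group in place of the methoxy group of 4-methoxyphenyl would read in this assay.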